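The source may report more compounds than this note shows. Statements on the series, on what has been measured and on what is new or still open speak of the compounds shown alone.

Working notes on the series. Compound 1 `CCn1c(=O)/c(=C2\Sc3ccccc3N2C)s/c1=C\c1ccncc1Nc1ccccc1F` is the reference point. In a functional assay on PC-3 cells (Homo sapiens) for inhibition (a lower number here means a stronger inhibitor, a higher number a weaker inhibitor), compound 1 gives 360 nM, the second highest of the three numbers in hand. Its nearest neighbour is compound 2 `CCn1c(=O)/c(=C2\Sc3cc(F)ccc3N2C)s/c1=C\c1ccncc1Nc1ccccc1F`, which in this assay gives 260 nM; the step of a 1.4-fold lower number from compound 1 to compound 2 (0.14 log units; within the scatter) amounts to fluoro in place of hydrogen on an aromatic carbon of the core. Furthest off is compound 3 `CCn1c(=O)/c(=C2\Sc3ccc(C)cc3N2C)s/c1=C\c1ccncc1Nc1ccccc1Cl`, which in this assay gives 500 nM; compound 3 differs from compound 1 in two places, so its number is noted alongside that of compound 1 without a step being drawn between them, and the two values lie within the scatter of each other.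

Compound 4 `CCn1c(=O)/c(=C2\Sc3ccccc3N2C)s/c1=C\c1ccncc1Nc1ccccc1C` is not yet measured. The change from compound 1 is methyl in place of fluoro on an aromatic carbon, placed ortho to a large group on the six-membered aromatic ring of carbon only. For the measured compounds named here, no measured step touches this position directly: the one step in hand, from compound 1 to compound 2, concerns a different ring and stays within the scatter, and compound 3, which carries chloro at this place but also a methyl elsewhere, sits within the scatter of compound 1. The expectation for this assay is therefore no step beyond the scatter in either direction, as no change at the digits printed from compound 1 to compound 4 (within the scatter) expresses. Compound 4 is estimated at 360 nM, with a range from 150 nM to 900 nM.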

Compound 4, half-maximal inhibitory concentration: 1200 nM
Compound 4: middle estimate off by 3.3-fold (0.52 log units), on the low side, and the stated range ends below it.
By their numbers in this assay, from the lowest: compounds 2, 1 and 3 (each within the scatter of the next); then compound 4.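

Changing 2-fluorophenyl to 2-methylphenyl on the core of compound 1 gives, in this assay, a 3.3-fold higher number from compound 1 to compound 4 (0.52 log units; beyond the scatter). For the compounds shown here, this is the first step to lie beyond the scatter, and it shows that this place on the six-membered aromatic ring of carbon only, ortho to a large group, does not tolerate every exchange of one heavy atom; the only earlier step, a 1.4-fold lower number from compound 1 to compound 2 (0.14 log units; within the scatter), concerned a different ring and did not reach beyond the scatter. What lies behind the step cannot be said, as no accompanying measurement addresses it.

The compounds shown leave open how a methoxy group, an amine, a carboxylic acid or a longer chain such as ethyl would read at this place, and where plain hydrogen would fall relative to fluoro and methyl. Also open, as far as these compounds go, is whether chloro alone on the core of compound 1 would read with fluoro or with methyl, and whether the same exchange would give a step of similar size on the fluorinated core of compound 2, as compound 3 carries a second change and so gives no direct reading.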